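Following a Trifluoromethyl Step from Compound 3 to Compound 4

The compounds below may be only part of what the source reports. "The series", "measured", "known", "first", "only" and "open" are said of these compounds alone.

Of the compounds shown here, three built on one shared core have been tested in an ADME assay on MDBK cells (Bos taurus) for cytotoxicity, read by MTT assay, with a stated time of 96 h; a lower number here means that less compound is tolerated, a higher number that more compound is tolerated. Compound 1 `CC(=O)c1ccc2[nH]c(-c3ccccc3)nc2c1` is the simplest of them. In this assay compound 1 gives > 100000 nM, which is a limit of the assay rather than a measured number. Compound 2 `CC(=O)c1ccc2[nH]c(-c3ccc(C(F)(F)F)cc3)nc2c1` differs from it by a step that the two limits leave unreadable from compound 1 to compound 2. In this assay compound 2 gives > 100000 nM, again a limit. Compound 3 `C/C(=N\NC(N)=O)c1ccc2[nH]c(-c3ccccc3)nc2c1` differs from compound 1 by a step that the two limits leave unreadable from compound 1 to compound 3. In this assay compound 3 gives > 100000 nM, also a limit. Compound 3 therefore stands where all three measured values stand, described by the limit of > 100000 nM in this assay, at which 3 of the 3 values shown sit; nothing separates it from the others.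

Compound 4 `C/C(=N\NC(N)=O)c1ccc2[nH]c(-c3ccc(C(F)(F)F)cc3)nc2c1` is not yet measured. It differs from compound 3 by trifluoromethyl in place of hydrogen on an aromatic carbon. The same change appears once among the measured pairs, from compound 1 to compound 2, but both ends of that step are limits, so its size cannot be read, and the step from compound 1 to compound 3 is unreadable for the same reason. With no readable step to lean on, the expectation is that compound 4 also sits at the limit, a step that the limit leaves unreadable from compound 3 to compound 4 being expected. Compound 4 is thus estimated at 150000 nM, within 80000 nM to 300000 nM.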

Compound 4, half-maximal cytotoxic concentration: > 100000 nM
Compound 4 was reported as a limit; the forecaster's own chance of this, stated with the estimate: 85%; the middle value lies beyond the limit too.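

In this assay compound 4 gives > 100000 nM, which is a limit of the assay and not a number. Its steps from compound 2 and from compound 3 therefore cannot be read. The compounds shown leave open whether trifluoromethyl or the larger group changes the result in this assay at all, because every value stands at the same place: the limit of > 100000 nM in this assay, at which 4 of the 4 values shown sit.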